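Notes on a phenyl addition to compound 2

The source may hold more compounds than are shown below. What is called first, only, known or untested is meant among the compounds shown, and "the series" means these compounds.

- compound 1 `Clc1ccc2c(NCCN3CCN(C(c4ccccc4)c4ccccc4)CC3)ccnc2c1` gives 3300 nM in the series
- compound 2 `Clc1ccc2c(NCCCN3CCN(C(c4ccccc4)c4ccccc4)CC3)ccnc2c1` gives 3000 nM in the series

Among the measured compounds shown here, both values come from an assay for binding affinity, with a stated time of 4 h (on this read-out higher numbers stand for weaker binding and lower numbers for tighter binding), and are the only measurements so far. Compound 2 (3000 nM) lies within the usual scatter of compound 1 (3300 nM), so the pair cannot be ranked and the series has a single level of binding to work from.

Compound 3 `Clc1ccc2c(NCCCN3CCN(C(c4ccccc4)(c4ccccc4)c4ccccc4)CC3)ccnc2c1` differs from compound 2 by one change (phenyl in place of hydrogen on a saturated chain carbon bound to an amine nitrogen in a ring and two aromatic carbons): phenyl in place of hydrogen on a saturated chain carbon bound to an amine nitrogen in a ring and two aromatic carbons.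

For the measured compounds named here, no measured pair shows this change, so the data give no size or direction for it in this assay. Going by the values given here, the only anchor is compound 2 (3000 nM). A modest step is expected, at or slightly beyond the scatter, with slightly weaker binding marginally favoured over tighter binding. The estimated step (a 1.2-fold higher number from compound 2 to compound 3 (0.07 log units; within the scatter)) is therefore small and uncertain. For compound 3 the expected value is 3500 nM with an estimated range from 1200 nM to 10000 nM in this read-out.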

Compound 3, dissociation constant: 5400 nM
Compound 3: middle estimate off by 1.5-fold (0.19 log units), on the low side, and the stated range covers the measured number.
By their numbers in this assay, from the lowest: compounds 2, 1 and 3 (each within the scatter of the next).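

In this assay, the saturated chain carbon bound to an amine nitrogen in a ring and two aromatic carbons now has its first reading for a change in substitution: with phenyl in place of hydrogen, the step is a 1.8-fold higher number from compound 2 to compound 3 (0.26 log units; within the scatter). The position therefore takes an added phenyl, with its 6 heavy atoms, without a difference in binding that can be told from repeat measurements, and this single step gives no direction for the change. Compound 1, compound 2 and compound 3 all remain at one level of binding, so the series still has no clear difference to build on, and no supporting measurement bears on the size of this step.

The compounds shown leave open whether a smaller group on this carbon, such as methyl or hydroxyl, or a larger one, such as benzyl, would give a step beyond the scatter. They also leave open whether a longer chain in compound 3 would give a number that can be told apart from the others.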